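From compound 3 to compound 4

The source may report more compounds than this note shows. Statements on the series, on what has been measured and on what is new or still open speak of the compounds shown alone.

In a functional assay on the whole organism with Rattus norvegicus as the target (a lower number here means that less compound is needed, a higher number that more compound is needed for the effect), compound 3 (`CCCC(=O)Nc1ccc(-c2csc(NC(=O)C(=O)OCC)n2)cc1`) gives > 10 mg/kg as a limit and not a number. Compound 1 (`CCOC(=O)C(=O)Nc1nc(-c2ccc(Sc3ccccc3)cc2)cs1`) gives > 3 mg/kg as a limit too. Compound 2 (`CCOC(=O)C(=O)Nc1nc(-c2ccc([N+](=O)[O-])cc2)cs1`) gives > 100 mg/kg as a limit as well. None of the three has a number yet, so compound 3 cannot be ranked against the other two.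

Compound 4 (`CCOC(=O)C(=O)Nc1ccc(-c2csc(NC(=O)C(=O)OCC)n2)cc1`) carries ethoxycarbonyl in place of propyl on a carbonyl carbon, so that (propylcarbonyl)amino becomes ((ethoxycarbonyl)carbonyl)amino. The measured steps bear on this only loosely, as all of them exchange a different group on an aromatic carbon: there is a step that the two limits leave unreadable from compound 1 to compound 2 and a step that the two limits leave unreadable from compound 1 to compound 3 as well. Since a step that the two limits leave unreadable from compound 2 to compound 3 gives no size either, no direction is expected, and no change beyond the scatter can be argued. The expected outcome in this assay is a step that the limit leaves unreadable from compound 3 to compound 4 as an estimate only. The estimate for compound 4 is 12 mg/kg with an expected range from 3 mg/kg to 50 mg/kg and a report as a limit is quite likely.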

Compound 4, dose for half-maximal effect: > 30 mg/kg
Compound 4: only a limit was reported; the forecaster's own chance of this, stated with the estimate: 60%; middle value at least 2.5-fold (0.39 log units) from the limit.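

In this assay compound 4 gives > 30 mg/kg as a limit and not a number. Within the data shown here, compound 1, compound 2 and compound 3 also carry only limits, so no step to compound 4 can be read. From the compounds shown here alone, the size of the effect of ethoxycarbonyl in place of propyl on a carbonyl carbon stays open, as does any ranking of these four compounds.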